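Swapping thiophene for furan on a weakly cytotoxic core

The compounds below may be only part of what the source reports. "The series", "measured", "known", "first", "only" and "open" are said of these compounds alone.

Measured compounds:
Compound 1 `COc1cc(-c2nnc3n2NC(c2cccs2)C(C(=O)c2ccc(F)cc2)S3)cc(OC)c1OC` — 43700 nM
Compound 2 `COc1cc(-c2nnc3n2NC(c2ccco2)C(C(=O)c2ccc(C)cc2)S3)cc(OC)c1OC` — > 100000 nM
Compound 3 `COc1cc(-c2nnc3n2NC(c2ccco2)C(C(=O)c2ccccc2C)S3)cc(OC)c1OC` — 69900 nM

In a functional assay on MCF7 cells (Homo sapiens) for cytotoxicity, read by MTT assay, with a stated time of 48 h (on this read-out higher numbers stand for weaker inhibition and lower numbers for stronger inhibition), compound 1 gives 43700 nM. Compound 3 gives 69900 nM, and the two numbers lie within the usual scatter of each other. For compound 2 the assay reports only a limit, > 100000 nM, not a number (the limit of > 100000 nM in this assay, at which 1 of the 3 values shown sits). Among the compounds with values here, compound 1 thus stands as one of only two numbers measured here.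

Compound 4 `COc1cc(-c2nnc3n2NC(c2ccco2)C(C(=O)c2ccc(F)cc2)S3)cc(OC)c1OC` differs from compound 1 in one place: furan-2-yl in place of thiophen-2-yl on a saturated ring carbon. Within the data shown here, no measured step changes this ring alone. Among the measured compounds shown here, the single measured step, an at least 1.4-fold lower number from compound 2 to compound 3 (0.15 log units; that floor lies within the scatter), concerns a different group and its floor lies within the scatter, so it says nothing about the change here. Both furan compounds, compound 2 and compound 3, give weaker results than compound 1, but they also carry different carbonyl aryl groups, so no clean reading follows.

Compound 4 is therefore expected to give 70000 nM, between 30000 nM and 150000 nM, which means an expected step of a 1.6-fold higher number from compound 1 to compound 4 (0.20 log units; within the scatter).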

Compound 4, half-maximal inhibitory concentration: > 100000 nM
Compound 4 was reported as a limit; the forecaster's own chance of this, stated with the estimate: 35%; middle value at least 1.4-fold (0.15 log units) from the limit.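

In this assay furan-2-yl in place of thiophen-2-yl, with the rest of the molecule unchanged, gives an at least 2.2-fold higher number from compound 1 to compound 4 (0.35 log units; beyond the scatter) and so shows that this saturated ring carbon responds to an exchange between two five-membered aromatic rings. Compound 4 is reported only as a limit, so the printed size of this step is a floor: the limit of > 100000 nM in this assay, at which 2 of the 4 values shown sit. The change of carbonyl aryl group gives an at least 1.4-fold higher number from compound 3 to compound 4 (0.15 log units; that floor lies within the scatter) and so does not separate 4-fluorophenyl from 2-methylphenyl, while the step between the two limits cannot be read.

From the compounds shown here alone, it remains open whether thiophen-2-yl would give a similar difference alongside a 2-methylphenyl or 4-methylphenyl group on the carbonyl carbon. Going by these compounds, it is also open how this ring carbon would respond to something other than a five-membered aromatic ring, such as a phenyl ring or an amine.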